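Swapping an Anilide for a Morpholine Amide

This account rests on a few compounds, and the source may have more. Where it says the series, first, only, none or still open, it means among the compounds named here.

Of the compounds shown here, two from this set have numbers so far. In a functional assay on Bel-7402 cells (Homo sapiens) for antiproliferative activity, read by MTT assay (on this read-out lower numbers stand for stronger inhibition and higher numbers for weaker inhibition), compound 1 `Cc1cccc(NC(=O)/C(C#N)=C/c2cc(O)c(O)c([N+](=O)[O-])c2)c1` gives 13.1 ug/mL, the lowest of the two numbers. In this assay compound 2 `COc1c(O)ccc(/C=C(\C#N)C(=O)Nc2cccc(Cl)c2)c1[N+](=O)[O-]` gives 65.3 ug/mL, a higher number, and the gap between the two lies beyond the usual scatter of such measurements.

Compound 3 `N#C/C(=C\c1cc(O)c(O)c([N+](=O)[O-])c1)C(=O)N1CCOCC1` has not been measured yet. It differs from compound 1 in one place: morpholin-4-yl in place of (3-methylphenyl)amino on a carbonyl carbon. Among the measured compounds shown here, no measured pair shows a change of this kind, so there is nothing in the numbers to calibrate against, and the expectation rests on the structures alone. In this assay the step of a 2.3-fold higher number from compound 1 to compound 3 (0.36 log units; beyond the scatter) is expected to move toward a higher number, that is, toward weaker inhibition, by a modest amount. On that basis compound 3 is estimated at 30 ug/mL, with a likely range from 10 ug/mL to 90 ug/mL.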

Compound 3, half-maximal inhibitory concentration: > 100 ug/mL
Compound 3: no number, only a limit; the forecaster's own chance of this, stated with the estimate: 15%; middle value at least 3.3-fold (0.52 log units) from the limit.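

Compound 3 has no number in this assay, only a limit of the assay: the limit of > 100 ug/mL in this assay, at which 1 of the 3 values shown sits.

Among the compounds shown here, on this carbonyl carbon, putting morpholin-4-yl in place of (3-methylphenyl)amino gives an at least 7.6-fold higher number from compound 1 to compound 3 (0.88 log units; beyond the scatter), the first reading for any change at this place, and it shows that the shared core alone does not carry the inhibition seen with compound 1. The swap removes an aromatic ring and a hydrogen-bond donor together and brings in a non-aromatic ring with a hydrogen-bond acceptor, so this single step cannot say which of these differences matters.

From the compounds shown here alone, it remains open whether the aromatic ring or the amide hydrogen counts for more, and a cyclohexylamino group, which has the amide hydrogen but no aromatic ring, would separate the two. A piperidin-1-yl group would likewise show whether the ring oxygen of morpholine plays any part.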